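Changing one side chain in a cell toxicity test

The source may report more compounds than this note shows. Statements on the series, on what has been measured and on what is new or still open speak of the compounds shown alone.

- compound 1 `CCN(CC)C(=O)CNC1CC2(N3CCN(C)CC3)CC(c3ccccc3)C1C(c1ccccc1)C2` gives 37900 nM
- compound 2 `CN1CCN(C23CCN(CCCN4CCCCC4)C(C(c4ccccc4)C2)C(c2ccccc2)C3)CC1` gives 28900 nM
- compound 3 `CN1CCN(C23CC(NC(=O)CCN4CCCC4)C(C(c4ccccc4)C2)C(c2ccccc2)C3)CC1` is not yet measured

In an ADME assay on L6 cells (Rattus norvegicus) for cytotoxicity, read by fluorescence, with a stated time of 72 h (on this read-out lower numbers stand for stronger inhibition and higher numbers for weaker inhibition), compound 1 gives 37900 nM and compound 2 gives 28900 nM so the two stand within the usual scatter of each other. Compound 3 carries (2-(pyrrolidin-1-yl)ethyl)carbonyl in place of (diethylcarbamoyl)methyl on an amine nitrogen. Going by the values given here, no measured pair differs in just one place, so the expectation leans only on those two values. The estimated step of a 1.3-fold lower number from compound 1 to compound 3 (0.10 log units; within the scatter) stays within the scatter, with no direction expected. Compound 3 is expected at 30000 nM with a likely range from 12000 nM to 70000 nM as an estimate.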

Compound 3, half-maximal inhibitory concentration: 42200 nM
Estimate against measurement, compound 3: 1.4-fold (0.15 log units) below, and the stated range covers the measured number.
By their numbers in this assay, from the lowest: compounds 2, 1 and 3 (each within the scatter of the next).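

In this assay, going by these compounds alone, the swap of (diethylcarbamoyl)methyl for (2-(pyrrolidin-1-yl)ethyl)carbonyl on an amine nitrogen is the first single-place step available (a 1.1-fold higher number from compound 1 to compound 3 (0.05 log units; within the scatter)). It shows that this position can take a five-membered non-aromatic ring and one more hydrogen-bond acceptor with no change in the number beyond the scatter. Nothing available offers an explanation for this result. Still open, on these data alone, is whether a longer chain, a carboxylic acid or a plain amine in this place would move the number beyond the scatter.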